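A few compounds are considered here, and "the series" means these few. Any claim that something is new, unique, unknown or untested is made for them only; others in the source may bear on it.

Measured in an ADME assay on L1210/0 cells (Mus musculus) for cytotoxicity, with a stated time of 48 h; a higher number here means a weaker inhibitor, a lower number a stronger inhibitor:
- Compound 1 `Nc1nc2c(nc(I)n2COCCO)c(=O)[nH]1`: 111000 nM
- Compound 2 `[N-]=[N+]=NCc1cn([C@H]2C[C@H](O)[C@@H](CO)O2)c(=O)[nH]c1=O`: 124000 nM
- Compound 3 `O=C(CI)NCc1cn([C@H]2C[C@H](O)[C@@H](CO)O2)c(=O)[nH]c1=O`: 107000 nM

These three values all lie within the scatter of one another, so the place of compound 1 among them carries no rank. Compound 1, at 111000 nM, serves as the starting point for the unmeasured compound 4 `CN(C)c1nc2c(=O)[nH]c(N)nc2n1COCCO`.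

The change from one to the other is dimethylamino in place of iodo on an aromatic carbon. In words, it is dimethylamino in place of iodo on an aromatic carbon, between two ring nitrogen atoms and next to the ring atom that bears the (2-hydroxyethoxy)methyl group.

Among the compounds with values here, only one measured step is available, and it bears on this change only indirectly. That step, a 1.2-fold lower number from compound 2 to compound 3 (0.06 log units; within the scatter), replaces a different group on a saturated chain carbon bound to an aromatic carbon, on another core. It lies within the scatter. Within the data shown here, no measured compound tests a replacement of iodo, so the expectation in this assay is loose: no step beyond the scatter, and no direction can be favoured with confidence.

The expected change is a 1.1-fold higher number from compound 1 to compound 4 (0.03 log units; within the scatter). For compound 4 the estimated value is 120000 nM, with an expected range from 50000 nM to 300000 nM.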

Compound 4, half-maximal inhibitory concentration: > 200000 nM
Compound 4 gave a limit, no number; the forecaster's own chance of this, stated with the estimate: 35%; middle value at least 1.6-fold (0.22 log units) away from the limit.
By their numbers in this assay, from the lowest: compounds 3, 1 and 2 (each within the scatter of the next). At a limit, above all of these: compound 4.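

Compound 4 gives only a limit in this assay: the limit of > 200000 nM in this assay, at which 1 of the 4 values shown sits.

Within the data shown here, this is the first reading for any replacement of iodo on this aromatic carbon, between two ring nitrogen atoms, and it comes as an at least 1.8-fold higher number from compound 1 to compound 4 (0.25 log units; that floor lies within the scatter), a step with a floor but no upper end. Among these compounds, it shows that dimethylamino at this place does not bring a lower number than iodo does in this assay, something the earlier compounds, which tested no change here, could not show. It does not establish a loss beyond the scatter, and how far apart the two compounds really stand cannot be read.

What the compounds shown leave open is whether a plain amino group, a methylamino group or a smaller halogen such as chloro on this aromatic carbon would read like compound 1 or like compound 4. They also leave open whether a longer chain on the entering nitrogen would give a number at all, with the (2-hydroxyethoxy)methyl group kept in place.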